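This account rests on a few compounds, and the source may have more. Where it says the series, first, only, none or still open, it means among the compounds named here.

Working notes on the series.

In a functional assay on KYSE-450 cells (Homo sapiens) for inhibition, read by MTT assay, with a stated time of 48 h (on this read-out higher numbers stand for weaker inhibition and lower numbers for stronger inhibition), compound 1 `C#CC(=O)N(Cc1ccc(OC)c(O)c1)c1cc(OC)c(OC)c(OC)c1` gives 570 nM, the lowest of the three numbers recorded so far. Compound 3 `COc1ccc(CNc2cc(OC)c(OC)c(OC)c2)cc1[N+](=O)[O-]` gives 16800 nM, and compound 2 `COc1ccc(N(Cc2cc(OC)c(OC)c(OC)c2)C(=O)CCl)cc1O` gives 29800 nM; both of these lie well beyond the scatter of repeats from compound 1, so compound 1 stands clearly apart, while compounds 2 and 3 differ from it in more than one place and their values show only the size of the gap, not which change carries it.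

Going by the values given here, compound 4 `C/C=C/C(=O)N(Cc1ccc(OC)c(O)c1)c1cc(OC)c(OC)c(OC)c1` keeps the shared core of compound 1 and is changed at a single point: prop-1-en-1-yl in place of ethynyl on a carbonyl carbon No measured pair in the set shows this exchange on its own, so the expected step rests on the numbers above only. Compound 4 is expected to give a higher number in this assay than compound 1, a step of a 6.1-fold higher number from compound 1 to compound 4 (0.79 log units; beyond the scatter), beyond the usual scatter but short of the gaps seen for compounds 2 and 3. The estimate for compound 4 in this assay is 3500 nM, with a likely range from 900 nM to 14000 nM, and the measured value will settle the point.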

Compound 4, half-maximal inhibitory concentration: 67 nM
Beside the measured number, compound 4's estimate is 52-fold (1.72 log units) above it; measured number below the stated range.
By their numbers in this assay, from the lowest: compound 4; then compound 1; then compounds 3 and 2 (each within the scatter of the next).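

At the carbonyl carbon whose other neighbour is the amide-type nitrogen, prop-1-en-1-yl in place of ethynyl gives an 8.5-fold lower number from compound 1 to compound 4 (0.93 log units; beyond the scatter) in this assay. Going by these compounds alone, this is the first change that can be read on its own, since compounds 2 and 3 differ from compound 1 in more than one place: the triple bond is not needed at this position for a low number, and a chain of 3 carbons with a double bond is accepted there, with compound 4 at 67 nM against compound 1 at 570 nM. Nothing measured here accounts for the size or direction of this step.

This single pair changes the bond type and the chain length together, so it cannot say which of the two carries the step; ethenyl and propyl on the same carbonyl would separate them. It also leaves open how far the position tolerates further growth, for example a longer chain or one ending in a dimethylamino group, and whether the step holds on other versions of the shared core.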